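This account rests on a few compounds, and the source may have more. Where it says the series, first, only, none or still open, it means among the compounds named here.

Measured compounds:
compound 1 `COc1cccc(-c2nc(SC)nc3sc(C(=O)NN)c(N)c23)c1` — in a functional assay on HEK293 cells for agonist activity at Thyrotropin receptor (Homo sapiens), read by cAMP accumulation (on this read-out higher numbers stand for larger maximal responses and lower numbers for smaller maximal responses), compound 1 gives 6.1%
compound 2 `COc1cccc(-c2nc(SC)nc3sc(C(=O)NNC(C)(C)C)c(N)c23)c1` — in this assay compound 2 gives 6.4%

Going by the values given here, compound 2 sits at the top of the two numbers, but only nominally: the one step between measured compounds, a number 0.3 percentage points higher from compound 1 to compound 2 (within the scatter), lies within the scatter, so compound 1 and compound 2 are indistinguishable on this read-out. Both are low-efficacy compounds.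

The next compound is compound 3 `COc1cccc(-c2nc(SC)nc3sc(C(=O)NNC(=O)OC(C)(C)C)c(N)c23)c1`. Its change from compound 2 is tert-butoxycarbonyl in place of tert-butyl on an amine nitrogen. Among the compounds with values here, the only measured step that bears on this place is the one from hydrogen to tert-butyl on the same amine nitrogen, a number 0.3 percentage points higher from compound 1 to compound 2 (within the scatter), which did nothing beyond the scatter. Within the data shown here, replacing tert-butyl by tert-butoxycarbonyl at that nitrogen introduces two hydrogen-bond acceptors and a double bond outside aromatic rings, but there is no measured step that tells how such a group behaves here. With the series showing no movement at this nitrogen so far, the expectation is a step of a number 0.1 percentage points higher from compound 2 to compound 3 (within the scatter), that is, none beyond the scatter. Compound 3 is therefore estimated at 6.5% in this assay, with a range from 0% to 20%.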

Compound 3, largest response reached (reported as efficacy), in percent of the reference or control that the assay uses: 1.9%
For compound 3 the middle estimate is 4.6 percentage points above the measured one, within the range that was stated.
By their numbers in this assay, from the lowest: compounds 3, 1 and 2 (each within the scatter of the next).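

At this amine nitrogen, the change to tert-butoxycarbonyl in this assay gives a number 4.5 percentage points lower from compound 2 to compound 3 (within the scatter), and the same group in place of hydrogen gives a number 4.2 percentage points lower from compound 1 to compound 3 (within the scatter). Going by these compounds alone, the position has now carried hydrogen, tert-butyl and tert-butoxycarbonyl, the last with a carbonyl and two hydrogen-bond acceptors, and no step among the three compounds lies beyond the scatter, so adding these acceptors does not separate compound 3 from compound 1 or compound 2 on this read-out. No supporting data bear on the reason for these numbers.

Still open, from the compounds shown here alone, is whether any group on this nitrogen can move the maximal response beyond the scatter, for example a benzoyl group, an aminoethyl chain or a carboxylic acid on a longer chain. Also open, going by these compounds, is how changes elsewhere on the shared core would read, as all three compounds carry that core unchanged and differ only on this nitrogen.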